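A few compounds are considered here, and "the series" means these few. Any claim that something is new, unique, unknown or untested is made for them only; others in the source may bear on it.

In an ADME assay on CEM-SS cells (Homo sapiens) for cytotoxicity, read by XTT assay (a higher number here means that more compound is tolerated, a lower number that less compound is tolerated), two compounds have been measured so far. Compound 1 `CN(O)C(=O)c1cc2ccn(Cc3ccc(F)cc3F)c2cn1` gives a firm number, 200000 nM. Compound 2 `CN1CCN(Cc2cn(Cc3ccc(F)cc3)c3cnc(C(=O)N(C)O)cc23)CC1` is reported only as a limit, > 224000 nM. Compound 2 therefore stands at the limit of > 224000 nM in this assay, at which 1 of the 2 values shown sits, and it has no exact figure of its own.

Compound 3 `COCc1cn(Cc2ccc(F)cc2)c2cnc(C(=O)N(C)O)cc12` departs from compound 2 in one place, with methoxy in place of 4-methylpiperazin-1-yl on a saturated chain carbon bound to an aromatic carbon. Among the compounds with values here, no step between measured compounds bears on this change, so any forecast in this assay has little to stand on. Within the data shown here, the only firm number is that of compound 1, at 200000 nM, and the expectation is anchored there. A small shift towards less compound being tolerated is expected, possibly none beyond the scatter. The expected change is an at least 1.2-fold lower number from compound 2 to compound 3 (0.09 log units; that floor lies within the scatter). Compound 3 is estimated at 180000 nM, with an expected range from 70000 nM to 300000 nM.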

Compound 3, half-maximal cytotoxic concentration: 266000 nM
Compound 3: middle estimate off by 1.5-fold (0.17 log units), on the low side; measured number inside the range.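

No step can be read from compound 2 to compound 3 in this assay, because compound 2 is reported only as a limit and has no exact number of its own: the limit of > 224000 nM in this assay, at which 1 of the 3 values shown sits.

The compounds shown leave open how far, and in which direction, methoxy in place of 4-methylpiperazin-1-yl moves the tolerated concentration.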